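The source may report more compounds than this note shows. Statements on the series, on what has been measured and on what is new or still open speak of the compounds shown alone.

Measured so far:
Compound 1 `O=S(=O)(c1ccc(F)cc1)c1cnc2cc(F)ccc2c1-c1cccc(F)c1`, in an ADME assay on microsomes from liver (Homo sapiens) for metabolic stability, tested at 2.5 uM; a higher number here means faster removal of the compound, a lower number slower removal: 0.95 mL/min
Compound 2 `COc1ccc(S(=O)(=O)c2cnc3cc(F)ccc3c2-c2ccc(F)cc2)cc1`, in this assay: 1.71 mL/min

For the measured compounds named here, only two compounds have been measured, and no step between them can be stated, since they differ from each other in more than one place. In this assay compound 2 gives 1.71 mL/min, and compound 1 gives 0.95 mL/min; the two numbers sit within the usual scatter of each other, so the data show no real separation between them. Compound 3 `COc1ccc(S(=O)(=O)c2cnc3cc(F)ccc3c2-c2cccc(F)c2)cc1` has not yet been measured. It differs from compound 2 in a single place: 3-fluorophenyl in place of 4-fluorophenyl on an aromatic carbon. Nothing measured here speaks directly to this change, so in this assay a step of no size beyond the scatter is expected, in either direction. Compound 3 is estimated at 1.5 mL/min, with a range from 0.8 mL/min to 2.8 mL/min, which corresponds to an expected step of a 1.1-fold lower number from compound 2 to compound 3 (0.06 log units; within the scatter).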

Compound 3, intrinsic clearance in a liver preparation (reported as CLH), per the amount of preparation that the assay uses: 2.94 mL/min
Compound 3: middle estimate off by 2.0-fold (0.29 log units), on the low side; the measured number lies above the stated range.
By their numbers in this assay, from the lowest: compounds 1, 2 and 3 (each within the scatter of the next, the first and the last beyond it).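

In this assay, 3-fluorophenyl in place of 4-fluorophenyl on an aromatic carbon gives a 1.7-fold higher number from compound 2 to compound 3 (0.24 log units; within the scatter), so the two fluorophenyl groups are not separated at this position. Methoxy in place of fluoro on an aromatic carbon gives a 3.1-fold higher number from compound 1 to compound 3 (0.49 log units; beyond the scatter), the first single-place change in this series to reach beyond the scatter, though only modestly. Nothing available bears on the reason for either step.

From the compounds shown here alone, whether the methoxy step would hold with 4-fluorophenyl in place of 3-fluorophenyl stays open, since compound 1 and compound 2 differ in more than one place. Also open, going by these compounds, is how a plain phenyl would compare with the two fluorophenyl groups at this position, and how an amine or a longer alkoxy chain would compare with methoxy.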